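A few compounds are considered here, and "the series" means these few. Any claim that something is new, unique, unknown or untested is made for them only; others in the source may bear on it.

Compound 1 `CC(=O)Nc1cccc(-c2ccc(C(O)(c3c[nH]cn3)C(C)C)cc2)c1`: 24 nM
Compound 2 `CC(=O)Nc1cccc(-c2ccc([C@](O)(c3c[nH]cn3)C(C)C)cc2)c1`: 26 nM
Compound 3 `CC(=O)Nc1cccc(-c2ccc([C@@](O)(c3c[nH]cn3)C(C)C)cc2)c1`: 340 nM

In an assay on isolated protein for inhibition of steroid 17-alpha-hydroxylase/17,20 lyase (Homo sapiens) (a higher number here means a weaker inhibitor, a lower number a stronger inhibitor), compound 1 has the lowest number of the three, though compound 2 lies within the scatter of it a 1.1-fold higher number from compound 1 to compound 2 (0.03 log units; within the scatter). Compound 3, which differs from compound 2 only in the configuration drawn (the fact that compounds 2 and 3 differ only in the configuration as drawn), is a much weaker inhibitor a 13-fold higher number from compound 2 to compound 3 (1.12 log units; beyond the scatter), and the same gap separates it from compound 1 a 14-fold higher number from compound 1 to compound 3 (1.15 log units; beyond the scatter). The step to compound 4 `CC(=O)Nc1cccc(-c2ccc(C(C)(O)c3c[nH]cn3)cc2)c1` is of another kind: methyl in place of isopropyl on a saturated chain carbon bound to two aromatic carbons and an oxygen on a saturated carbon. Within the data shown here, none of the measured steps alters this group; each concerns only how the configuration is drawn the fact that one of compounds 1 and 2 is drawn with a defined configuration and the other without, at the place where they differ (the fact that one of compounds 1 and 3 is drawn with a defined configuration and the other without, at the place where they differ), so they offer no guide to the size or direction of the change. Compound 4 is therefore expected to land near compound 1, with wide uncertainty, at 60 nM (range 15 nM to 250 nM), a step of a 2.5-fold higher number from compound 1 to compound 4 (0.40 log units; beyond the scatter).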

Compound 4, half-maximal inhibitory concentration: 38 nM
Compound 4: middle estimate off by 1.6-fold (0.20 log units), on the high side; low and high end bracket the measured number.
By their numbers in this assay, from the lowest: compounds 1, 2 and 4 (each within the scatter of the next); then compound 3.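

Among these compounds, the earlier compounds differ only in drawn configuration, while compound 4 is the first to change the group itself on this saturated chain carbon. In this assay, methyl in place of isopropyl gives a 1.6-fold higher number from compound 1 to compound 4 (0.20 log units; within the scatter), so inhibition in this range does not require isopropyl. Nothing measured here accounts for this result. On these data alone, compound 4 is drawn without a configuration, so it remains open whether its two mirror-image forms separate as widely as compound 2 and compound 3 do. A longer chain or a cyclohexyl group at this position also remains untested in the compounds shown.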